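The compounds below may be only part of what the source reports. "The series", "measured", "known", "first", "only" and "open" are said of these compounds alone.

The measured compounds:
Compound 1 `CCC(=O)N(Cc1ccc(OC)c(O)c1)c1cc(OC)c(OC)c(OC)c1`: 98 nM
Compound 2 `COc1ccc(CNc2cc(OC)c(OC)c(OC)c2)cc1C`: 73800 nM
Compound 3 `C/C=C/C(=O)N(Cc1ccc(OC)c(C)c1)c1cc(OC)c(OC)c(OC)c1`: 32900 nM

Within a functional assay on KYSE-450 cells (Homo sapiens) for inhibition, read by MTT assay, with a stated time of 48 h (a higher number here means a weaker inhibitor, a lower number a stronger inhibitor), compound 2 gives the highest number of the three. Compound 3 stands nearest to it: the step of a 2.2-fold lower number from compound 2 to compound 3 (0.35 log units; beyond the scatter) is modest and comes from a (prop-1-en-1-yl)carbonyl in place of hydrogen on a nitrogen on an aromatic ring. Among the compounds with values here, compound 1 is the furthest away; it differs from compound 2 in more than one place, so no single step between them can be stated, only that compound 1 gives a far lower number.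

Compound 4 `COc1ccc(CNc2cc(OC)c(OC)c(OC)c2)cc1` has not yet been measured. It differs from compound 2 by hydrogen in place of methyl on an aromatic carbon, on an aromatic carbon of a six-membered aromatic ring of carbon only, ortho to a methoxy group and meta to a large group. Within the data shown here, none of the measured steps touches this place; the only step concerns the nitrogen. With nothing to set a direction, the author expects for compound 4 in this assay a step of a 1.2-fold lower number from compound 2 to compound 4 (0.09 log units; within the scatter), not beyond the scatter. Compound 4 is therefore estimated at 60000 nM, within a range from 20000 nM to 180000 nM.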

Compound 4, half-maximal inhibitory concentration: 4890 nM
The estimate for compound 4 lay 12-fold (1.09 log units) above the measured number; the measured number lies below the stated range.
By their numbers in this assay, from the lowest: compound 1; then compound 4; then compound 3; then compound 2.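

In this assay, the aromatic carbon ortho to a methoxy group proves to be a sensitive place: hydrogen in place of methyl gives a large step (a 15-fold lower number from compound 2 to compound 4 (1.18 log units; beyond the scatter)). Within the data shown here, the only earlier single change, on the nitrogen, was modest (a 2.2-fold lower number from compound 2 to compound 3 (0.35 log units; beyond the scatter)), so the loss of a single carbon here moves the number further than that added (prop-1-en-1-yl)carbonyl did. No evidence at hand accounts for this step.

The compounds shown leave open whether a fluorine or a chlorine on this aromatic carbon would give a number nearer to that of compound 2 or that of compound 4. They also leave open whether hydrogen in place of methyl would give a similar step with the (prop-1-en-1-yl)carbonyl on the nitrogen, as in compound 3.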